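The source may report more compounds than this note shows. Statements on the series, on what has been measured and on what is new or still open speak of the compounds shown alone.

Measured compounds in a functional assay on U-937 cells (Homo sapiens) for cytotoxicity, read by MTT assay, with a stated time of 48 h; a lower number here means a stronger inhibitor, a higher number a weaker inhibitor:

compound 1, `Fc1cccc(Nc2nc(-c3cccc(F)c3)nc3ccc(F)cc23)c1`: 42300 nM
compound 2, `Fc1cccc(-c2nc(Nc3ccccc3F)c3cc(F)ccc3n2)c1`: > 50000 nM, a limit of the assay
compound 3, `Fc1cccc(-c2nc(Nc3ccccc3Cl)c3cc(F)ccc3n2)c1`: > 50000 nM, a limit of the assay

Where compound 3 stands: in this assay compound 3 gives > 50000 nM, which is a limit of the assay and not a number. Compound 2 likewise reaches only its limit, > 50000 nM. Compound 1 alone gives a number, 42300 nM; (the limit of > 50000 nM in this assay, at which 2 of the 3 values shown sit). The step of an at least 1.1-fold higher number from compound 1 to compound 3 (0.07 log units; that floor lies within the scatter) and the step of an at least 1.1-fold higher number from compound 1 to compound 2 (0.07 log units; that floor lies within the scatter) are both floors that lie within the scatter, and the halogen exchange a step that the two limits leave unreadable from compound 2 to compound 3 cannot be read at all.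

Compound 4, `Fc1cccc(-c2nc(Nc3ccccc3Br)c3cc(F)ccc3n2)c1`, is not yet measured. It differs from compound 3 as bromo in place of chloro on an aromatic carbon. Going by the values given here, the only measured step of the same kind, the exchange of one halogen on that ring, is a step that the two limits leave unreadable from compound 2 to compound 3, so nothing gives a direction or a size for this change. No step beyond the scatter is therefore expected in this assay; the estimated step is a step that the limit leaves unreadable from compound 3 to compound 4. Compound 4 is expected to give about 60000 nM in this assay, within 25000 nM to 200000 nM, most probably reported again as a limit.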

Compound 4, half-maximal inhibitory concentration: > 50000 nM
Compound 4 ended at the assay's limit (the forecaster's own chance of this, stated with the estimate: 75%); the middle value does not contradict the limit.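

With bromo, a third halogen on this aromatic carbon, ortho to a large group, compound 4 stays at the same limit of the assay as compound 2 and compound 3, so none of the three halogens gives a readable number in this assay: the limit of > 50000 nM in this assay, at which 3 of the 4 values shown sit.

The steps among compound 2, compound 3 and compound 4 cannot be read, and no order of fluoro, chloro and bromo follows from them. Going by these compounds alone, the one readable step is an at least 1.1-fold higher number from compound 1 to compound 4 (0.07 log units; that floor lies within the scatter), so 2-bromophenyl on that nitrogen is not separated from the 3-fluorophenyl of compound 1.

Open, as far as these compounds go, is whether a methoxy, an amine or a carboxylic acid on this aromatic carbon would give a number rather than a limit. Also open, from the compounds shown here alone, is how a 3-chlorophenyl or 3-bromophenyl on the nitrogen would compare with compound 1 at 42300 nM.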